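The source may hold more compounds than are shown below. What is called first, only, known or untested is meant among the compounds shown, and "the series" means these compounds.

Of the compounds shown here, two have been measured so far. Among the compounds with values here, in a functional assay on K562 cells (Homo sapiens) for cytotoxicity, read by MTT assay, with a stated time of 72 h (a higher number here means a weaker inhibitor, a lower number a stronger inhibitor), compound 2 (`COCOc1cc(/C=C/C(=O)OCC(=O)NN2CCOCC2)ccc1OCc1ccccc1`) gives 32400 nM, and it is the only compound with a number rather than a limit. For compound 1 (`COCOc1cc(/C=C/C(=O)OCC(=O)Nc2ccc(Cl)cc2)ccc1OCc1ccccc1`) the result is a limit and not a number, > 200000 nM. Within the data shown here, the single measured step, an at least 6.1-fold lower number from compound 1 to compound 2 (0.79 log units; beyond the scatter), rests on (the limit of > 200000 nM in this assay, at which 1 of the 2 values shown sits), so only its smallest size is known. Compound 3 (`COCOc1cc(/C=C/C(=O)OCC(=O)NCc2ccco2)ccc1OCc1ccccc1`) differs from compound 2 in the same place: (furan-2-yl)methyl in place of morpholin-4-yl on an amide-type nitrogen. Among the measured compounds shown here, in the one step seen, an aromatic ring on this amide-type nitrogen went with a limit and a non-aromatic ring with a number; that step, an at least 6.1-fold lower number from compound 1 to compound 2 (0.79 log units; beyond the scatter), makes a move beyond the scatter plausible here too, and the expected direction is towards a higher number, as the entering group brings an aromatic ring. The step from compound 2 to compound 3 is therefore estimated at a 1.9-fold higher number from compound 2 to compound 3 (0.27 log units; within the scatter). Compound 3 is expected to give about 60000 nM in this assay, within a range from 20000 nM to 200000 nM.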

Compound 3, half-maximal inhibitory concentration: 300 nM
The estimate for compound 3 lay 200-fold (2.30 log units) above the measured number; the measured number lies below the stated range.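

In this assay, within the data shown here, the amide-type nitrogen turns out to tolerate far more than the earlier compounds suggested, and (furan-2-yl)methyl in place of morpholin-4-yl gives a 110-fold lower number from compound 2 to compound 3 (2.03 log units; beyond the scatter), although both groups have the same count of heavy atoms and neither carries a net charge. Against the 4-chlorophenyl group, (furan-2-yl)methyl gives an at least 660-fold lower number from compound 1 to compound 3 (2.82 log units; beyond the scatter), and only the smallest size of this step is known: the limit of > 200000 nM in this assay, at which 1 of the 3 values shown sits. An aromatic ring on this nitrogen therefore does not by itself go with a weak result, since compound 1 and compound 3 both carry one, yet compound 3 has the lowest number of the three and compound 1 has only a limit.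

The furan ring and the carbon link that joins it to the nitrogen change together, so these compounds cannot show which of the two matters. Benzyl would test the link with a six-membered aromatic ring, furan-2-yl set directly on the nitrogen would test the loss of the link, and (tetrahydrofuran-2-yl)methyl would test whether the ring needs to be aromatic.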